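Chlorine to Fluorine on the Aryl Ketone: An Expectation

The source may hold more compounds than are shown below. What is called first, only, known or untested is meant among the compounds shown, and "the series" means these compounds.

Compound 1 `COc1cc(-c2cc(/C=C/C(=O)c3ccc(Cl)c(Cl)c3)[nH]n2)cc(OC)c1OC`: 96%
Compound 2 `COc1ccc(-c2cc(/C=C/C(=O)c3ccc(N)cc3)[nH]n2)cc1OC`: 90%
Compound 3 `COc1cc(C(=O)/C=C/c2cc(-c3cc(OC)c(OC)c(OC)c3)n[nH]2)cc(OC)c1OC`: 91%

Of the compounds shown here, three have been measured in a functional assay on UACC-257 cells (Homo sapiens) for cytotoxicity, read by sulforhodamine B assay, with a stated time of 48 h, tested at 0.1 uM; a higher number here means a weaker effect of the compound at the concentration tested, a lower number a stronger effect. Compound 1 shows the highest number of the three, yet compound 3 sits within the scatter of it, and so does compound 2, so no order among them can be claimed. Compound 4 `COc1cc(-c2cc(/C=C/C(=O)c3ccc(F)c(F)c3)[nH]n2)cc(OC)c1OC` differs from compound 1 in one place: 3,4-difluorophenyl in place of 3,4-dichlorophenyl on a carbonyl carbon. Within the data shown here, no measured pair shows what this exchange does in this assay, and the three known numbers all lie close together. The step from compound 1 to compound 4 is therefore expected to be none beyond the scatter, a number 2 percentage points lower from compound 1 to compound 4 (within the scatter). Compound 4 is expected to give about 94%, with a range from 82% to 104%.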

Compound 4, a percentage reported as activity, at one concentration (the size of the read-out at that concentration, not a potency): 92%
For compound 4 the middle estimate is 2 percentage points above the measured one; low and high end bracket the measured number.
By their numbers in this assay, from the lowest: compounds 2, 3, 4 and 1 (each within the scatter of the next).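

In this assay, putting 3,4-difluorophenyl in place of 3,4-dichlorophenyl on the carbonyl carbon gives a number 4 percentage points lower from compound 1 to compound 4 (within the scatter) and so provides the first direct test of a change at this position. This pair shows no effect of the exchange that can be separated from ordinary variation between repeated measurements. No measured information bears on this result.

As far as these compounds go, it remains open whether a nitrile or a carboxylic acid on this phenyl ring would move the number beyond the scatter. A reading at one concentration also leaves potency unsettled.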